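The compounds below may be only part of what the source reports. "The series", "measured", "known", "first", "only" and "open" are said of these compounds alone.

In a functional assay on NCI-H146 cells (Homo sapiens) for cytotoxicity, with a stated time of 48 h, in the presence of a further agent that is not named here (a lower number here means that less compound is needed, a higher number that more compound is needed for the effect), three compounds have been measured. Compound 2 (`CN(C)CC[C@H](CSc1ccccc1)Nc1ccc(S(=O)(=O)NC(=O)c2ccc(N3CCN(Cc4ccccc4-c4ccc(Cl)cc4)CC3)cc2)cc1S(C)(=O)=O`) gives 34900 nM and stands highest of the three numbers, beyond the scatter from both others. Compound 3 (`CN(C)CC[C@H](CSc1ccccc1)Nc1ccc(S(=O)(=O)NC(=O)c2ccc(N3CCN(CC4=C(c5ccc(Cl)cc5)CCOC4)CC3)cc2)cc1[N+](=O)[O-]`) comes nearest at 266 nM and compound 1 (`CN(C)CC[C@H](CSc1ccccc1)Nc1ccc(S(=O)(=O)NC(=O)c2ccc(N3CCN(CC4=C(c5ccc(Cl)cc5)CCCCC4)CC3)cc2)cc1[N+](=O)[O-]`) lies furthest at 51.9 nM from that top value.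

Compound 4 (`CN(C)CC[C@H](CSc1ccccc1)Nc1ccc(S(=O)(=O)NC(=O)c2ccc(N3CCN(Cc4ccccc4-c4ccc(Cl)cc4)CC3)cc2)cc1OC(F)(F)F`) is compound 2 with trifluoromethoxy in place of methylsulfonyl on an aromatic carbon, ortho to a large group and meta to a large group (trifluoromethoxy in place of methylsulfonyl on an aromatic carbon). Among the measured compounds shown here, no two measured compounds differ in one place only, so the data give no direct measure of this change. Compound 2 at 34900 nM sits at the top of the measured numbers, which leaves more room downward than upward, and a lower number is therefore expected. In this assay the estimated step of a 4.4-fold lower number from compound 2 to compound 4 (0.64 log units; beyond the scatter) is expected to be a moderate drop beyond the scatter, though this rests on little evidence. Compound 4 is estimated at 8000 nM with an expected range from 1500 nM to 40000 nM for that compound.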

Compound 4, half-maximal effective concentration: 5080 nM
For compound 4 the middle estimate is 1.6-fold (0.20 log units) above the measured one, within the range that was stated.
By their numbers in this assay, from the lowest: compound 1; then compound 3; then compound 4; then compound 2.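

In this assay, among the compounds shown here, the pair gives the first direct reading of this position, an aromatic carbon ortho to a large group and meta to a large group: trifluoromethoxy in place of methylsulfonyl brings a 6.9-fold lower number from compound 2 to compound 4 (0.84 log units; beyond the scatter) and is a modest step. For the compounds shown here, it shows that the number responds to the group at this position with the rest of compound 2 unchanged, which the earlier compounds could not show, as no two of them differ in one place only. Nothing measured here accounts for the step.

Open, going by these compounds, is how a nitrile, an amine or a plain hydrogen would read at this position on the same core. Also open, on these data alone, is whether this step would keep its direction and size on the core of compound 1 or compound 3.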